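Chromone Amines: Swapping a Benzyl Arm for Naphthylmethyl

The source may report more compounds than this note shows. Statements on the series, on what has been measured and on what is new or still open speak of the compounds shown alone.

Compound 1 `Cc1cc(=O)c2ccc(O)c(CN(Cc3ccccc3)Cc3ccccc3)c2o1` and compound 2 `COc1ccc(CN(Cc2ccccc2)Cc2c(O)ccc3c(=O)cc(C)oc23)cc1` share a chromone core carrying a hydroxyl and a tertiary amine with two arylmethyl arms. In a functional assay on A549 cells (Homo sapiens) for inhibition, read by sulforhodamine B assay, with a stated time of 72 h (on this read-out higher numbers stand for weaker inhibition and lower numbers for stronger inhibition), compound 1 gives 11.9 ug/mL, and compound 2 gives 14.1 ug/mL. For the measured compounds named here, the only step between them, a 1.2-fold higher number from compound 1 to compound 2 (0.07 log units; within the scatter), leaves the two within the scatter of each other, so neither can be called the more active. Compound 2 holds the highest of the two numbers, but its nearest neighbour, compound 1, sits within the scatter.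

Compound 3 `COc1ccc(CN(Cc2ccc3ccccc3c2)Cc2c(O)ccc3c(=O)cc(C)oc23)cc1` differs from compound 2 in one place: naphthalen-2-yl in place of phenyl on a saturated chain carbon bound to an amine nitrogen. Going by the values given here, no measured step touches this arm of the molecule; the single step available concerns the other arm and was within the scatter. There is therefore no basis from the data for expecting a shift in this assay beyond the scatter in either direction.

Compound 3 is estimated at 12 ug/mL, within 5 ug/mL to 30 ug/mL. The step this estimate means, a 1.2-fold lower number from compound 2 to compound 3 (0.07 log units; within the scatter), is expected to stay within the scatter.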

Compound 3, half-maximal inhibitory concentration: 6.01 ug/mL
For compound 3 the middle estimate is 2.0-fold (0.30 log units) above the measured one; low and high end bracket the measured number.
By their numbers in this assay, from the lowest: compounds 3, 1 and 2 (each within the scatter of the next, the first and the last beyond it).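

In this assay, for the compounds shown here, the swap of benzyl for (naphthalen-2-yl)methyl gives a 2.3-fold lower number from compound 2 to compound 3 (0.37 log units; beyond the scatter) and is the first step in this set to lie beyond the scatter, though only modestly. The methoxy change on the other arm did not move the number beyond the scatter, whereas replacing one six-membered aromatic ring with two on a saturated chain carbon bound to an amine nitrogen does, so this single pair shows that the read-out can respond to a change in the arylmethyl arms. Nothing available explains why the two-ring arm goes with the lower number.

As far as these compounds go, it remains open whether the shift depends on the particular naphthalen-2-yl arrangement or would also appear with a naphthalen-1-yl, biphenyl-4-yl or pyridin-3-yl group in the same place. Also unsettled is whether the same swap would give a similar step on compound 1, which lacks the methoxy group, or whether a second (naphthalen-2-yl)methyl arm in place of the remaining methoxy-bearing benzyl arm would lower the number further.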